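The compounds below may be only part of what the source reports. "The series", "measured", "known", "first", "only" and "open" are said of these compounds alone.

Measured so far in an assay on isolated protein for inhibition of Myeloperoxidase (Homo sapiens); a lower number here means a stronger inhibitor, a higher number a weaker inhibitor:
- compound 1 `NCCCc1c[nH]c2ccc(F)cc12`: 650 nM
- compound 2 `CNCCCc1c[nH]c2ccc(F)cc12`: 26 nM
- compound 3 `CCCNCCCc1c[nH]c2ccc(F)cc12`: 340 nM

Compound 3 sits second highest of the three numbers. Its nearest neighbour is compound 1, and the two lie within the scatter of each other (a 1.9-fold lower number from compound 1 to compound 3 (0.28 log units; within the scatter)); its furthest is compound 2, from which it is separated by a large step (a 13-fold higher number from compound 2 to compound 3 (1.12 log units; beyond the scatter)).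

Compound 4 `Fc1ccc2[nH]cc(CCCN3CCCC3)c2c1` has not yet been measured in this assay. The change is pyrrolidin-1-yl in place of propylamino on a saturated chain carbon, three bonds along the chain from an aromatic carbon: the propylamino group, with its one hydrogen-bond donor, gives way to a pyrrolidin-1-yl group carrying a five-membered non-aromatic ring and no donor.

For the measured compounds named here, none of the measured steps covers a ring closure or the loss of the donor. What bears on it indirectly: a single methyl on the amine nitrogen gave a large drop (a 25-fold lower number from compound 1 to compound 2 (1.40 log units; beyond the scatter)), whereas lengthening that group to propyl undid most of it (a 13-fold higher number from compound 2 to compound 3 (1.12 log units; beyond the scatter)) and left compound 3 close to compound 1. A second alkyl group on the nitrogen, as in compound 4, lies outside anything measured, so the direction is open and the expected step from compound 3 is taken as small, a 2.3-fold lower number from compound 3 to compound 4 (0.36 log units; beyond the scatter), with wide bounds. Compound 4 is estimated at 150 nM, within 30 nM to 700 nM.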

Compound 4, half-maximal inhibitory concentration: 210 nM
Compound 4: the middle estimate sits 1.4-fold (0.15 log units) below what was measured; measured number inside the range.
By their numbers in this assay, from the lowest: compound 2; then compounds 4, 3 and 1 (each within the scatter of the next, the first and the last beyond it).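

In this assay, pyrrolidin-1-yl in place of propylamino adds a five-membered non-aromatic ring and leaves this group with no hydrogen-bond donor, yet the result is a 1.6-fold lower number from compound 3 to compound 4 (0.21 log units; within the scatter), so at this position neither the ring closure nor the loss of the donor produces a readable difference. Methylamino remains apart from the ring, as shown by an 8.1-fold higher number from compound 2 to compound 4 (0.91 log units; beyond the scatter), while the ring also stands modestly clear of the plain amino group in a 3.1-fold lower number from compound 1 to compound 4 (0.49 log units; beyond the scatter), a separation that the propylamino group did not show. No measurement at hand gives a reason for any of these steps.

Dimethylamino would test whether the methyl group of compound 2 keeps its effect once the donor is gone, and ethylamino would show how quickly the low number of compound 2 is lost as the chain on the nitrogen grows. Piperidin-1-yl and azetidin-1-yl remain open for the dependence on ring size, as does a shorter or longer chain between the core and the amine.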